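The compounds below may be only part of what the source reports. "The series", "measured", "known", "first", "only" and "open" are said of these compounds alone.

Compound 1 `CC(=O)Nc1cccc(-c2ccc(C(=O)N(Cc3cccc(OCCCCCC(=O)O)c3)C(C)C)cc2)c1`: in an ADME assay on Raji cells (Homo sapiens) for cytotoxicity, read by CellTiter-Glo and resazurin assay, with a stated time of 72 h (on this read-out higher numbers stand for an effect only at larger amounts of compound and lower numbers for an effect already at smaller amounts), compound 1 shows only a limit, > 26000 nM.
Compound 2 `CCOC(=O)CCCCCOc1cccc(CN(C(=O)c2ccccc2)C(C)C)c1`: in this assay compound 2 shows only a limit, > 26000 nM.
Compound 3 `CCOC(=O)CCCCCOc1cccc(CN(C(=O)c2ccc(-c3cccc(N(C)C)c3)cc2)C(C)C)c1`: in this assay compound 3 shows only a limit, > 26000 nM.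

Compound 3 therefore stands at the limit, the same one at which every measured value sits (the limit of > 26000 nM in this assay, at which 3 of the 3 values shown sit). Among the compounds with values here, the only single-site step among the measured compounds, a step that the two limits leave unreadable from compound 2 to compound 3, is left unreadable by the two limits. Compound 4 `CCOC(=O)CCCCCOc1cccc(CN(C(=O)c2ccc(-c3cccc(NC(C)=O)c3)cc2)C(C)C)c1` differs from compound 3 by acetamido in place of dimethylamino on an aromatic carbon. With no readable step to draw on, compound 4 is expected to behave like compound 3 and to give, most probably, again only a limit. Compound 4 is estimated at 35000 nM, with a range from 15000 nM to 90000 nM. That corresponds to an expected step that the limit leaves unreadable from compound 3 to compound 4, which is not expected to exceed the scatter.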

Compound 4, half-maximal effective concentration: > 26000 nM
Compound 4: a limit, no number (the forecaster's own chance of this, stated with the estimate: 85%); the middle value lies beyond the limit too.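

Compound 4 gives only a limit, so no new step can be read from compound 1, compound 2 or compound 3 to compound 4: the limit of > 26000 nM in this assay, at which 4 of the 4 values shown sit.

In this assay the compounds shown leave open which structural change, if any, would give a number instead of a limit.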